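Aryl ketone in place of ester on the acrylonitrile arm

The source may report more compounds than this note shows. Statements on the series, on what has been measured and on what is new or still open speak of the compounds shown alone.

Compound 2 `COCCOC(=O)/C(C#N)=C/c1c(-c2ccccc2)[nH]c2ccccc12` carries a (2-methoxyethoxy)carbonyl group and, in a functional assay on HepG2 cells (Homo sapiens) for cytotoxicity, read by MTT assay, with a stated time of 96 h (a higher number here means that more compound is needed for the effect, a lower number that less compound is needed), compound 2 gives 85000 nM, the highest of the two numbers measured. Among the compounds with values here, its only measured neighbour is compound 1 `N#C/C(=C\c1c(-c2ccccc2)[nH]c2ccccc12)C(=O)c1cccs1`, which in this assay gives 25000 nM; the one measured step reads a 3.4-fold higher number from compound 1 to compound 2 (0.53 log units; beyond the scatter). Compound 3 `N#C/C(=C\c1c(-c2ccccc2)[nH]c2ccccc12)C(=O)c1ccc(Cl)cc1` is not yet measured; it differs from compound 2 by 4-chlorophenyl in place of 2-methoxyethoxy on a carbonyl carbon. This is the reverse kind of change to the measured step, an ester going back to an aryl ketone, so the expectation rests on compound 1 and on the size of a 3.4-fold higher number from compound 1 to compound 2 (0.53 log units; beyond the scatter). Compound 3 is therefore expected to give a lower number than compound 2, with an estimated step of a 3.4-fold lower number from compound 2 to compound 3 (0.53 log units; beyond the scatter). For compound 3 the estimate in this assay is 25000 nM, with a likely range from 8000 nM to 70000 nM.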

Compound 3, half-maximal effective concentration: 37000 nM
Compound 3: the middle estimate sits 1.5-fold (0.17 log units) below what was measured; low and high end bracket the measured number.
By their numbers in this assay, from the lowest: compounds 1 and 3 (each within the scatter of the next); then compound 2.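

On this carbonyl carbon, the gap first seen with thiophen-2-yl also appears with a second aromatic ring: in this assay, replacing 2-methoxyethoxy with 4-chlorophenyl gives a 2.3-fold lower number from compound 2 to compound 3 (0.36 log units; beyond the scatter), though this is a modest step. Exchanging thiophen-2-yl for 4-chlorophenyl gives a 1.5-fold higher number from compound 1 to compound 3 (0.17 log units; within the scatter), so these two aryl ketones cannot be told apart here, and among the three compounds the separation lies between the two ketones and the ester. No measurement at hand bears on what lies behind these numbers.

On these data alone, the ester side rests on compound 2 alone, so it remains open whether a simple ethoxy group would sit with compound 2 or with the ketones. Also open, as far as these compounds go, is where a methyl ketone or an amide formed from a morpholine amine would fall on this carbonyl carbon.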